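This account rests on a few compounds, and the source may have more. Where it says the series, first, only, none or still open, it means among the compounds named here.

Compound 2 `N#Cc1c(N2CCC(c3cccc(F)c3)CC2)ccn(CC2CC2)c1=O` has been tested in a functional assay on CHO cells for positive allosteric modulation of metabotropic glutamate receptor 2 (Homo sapiens), with a stated time of 30 min (a lower number here means a smaller maximal response, a higher number a larger maximal response), and gives 268%. Among the measured compounds shown here, of the two numbers measured so far this is the lower; the only other measured compound, compound 1 `N#Cc1c(N2CCC(c3ccccc3F)CC2)ccn(CC2CC2)c1=O`, gives 282% in this assay, and the single step between them, a number 14 percentage points lower from compound 1 to compound 2 (beyond the scatter), lies beyond the scatter. That step exchanges one fluorophenyl for another on the saturated ring carbon of the shared core. Compound 3 `N#Cc1c(N2CCC(c3ccc(F)cc3)CC2)ccn(CC2CC2)c1=O` has not yet been measured. It differs from compound 2 in one place only: 4-fluorophenyl in place of 3-fluorophenyl on a saturated ring carbon. For the measured compounds named here, the one step in hand, from compound 1 to compound 2, bears on this change directly, since it too alters which fluorophenyl sits on the saturated ring carbon, and it was modest. Going by the values given here, whether a further change of the fluorophenyl lowers or raises the maximal response cannot be read from a single step, and no measured compound carries the 4-fluorophenyl. Compound 3 is therefore expected to give about 260% in this assay, with a range from 220% to 300%. The expected step of a number 8 percentage points lower from compound 2 to compound 3 (within the scatter) is accordingly small, most likely within the scatter or a little below compound 2.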

Compound 3, largest response reached (Emax), in percent of the reference or control that the assay uses: 258%
The estimate for compound 3 lay 2 percentage points above the measured number; the measured number falls inside the stated range.
By their numbers in this assay, from the lowest: compounds 3 and 2 (each within the scatter of the next); then compound 1.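

Exchanging 3-fluorophenyl for 4-fluorophenyl on the saturated ring carbon gives, in this assay, a number 10 percentage points lower from compound 2 to compound 3 (within the scatter), so these two groups cannot be told apart at this position on the present numbers. The step of a number 24 percentage points lower from compound 1 to compound 3 (beyond the scatter) adds a second comparison against the 2-fluorophenyl of compound 1, which now has the largest maximal response of the three, by a modest margin, while compound 2 and compound 3 stay together; of the three fluorophenyl groups, only the 2-fluorophenyl stands apart. Nothing available explains why the 2-fluorophenyl differs from the other two groups at this position.

The compounds shown all carry a single fluorine on the phenyl ring, so they leave open how an unsubstituted phenyl, a chlorophenyl, a methoxyphenyl or a difluorophenyl would compare on this ring carbon. They also leave open whether the small gap among the fluorophenyl groups would persist with a pyridine or a cyclohexyl in place of the phenyl ring.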